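The source may report more compounds than this note shows. Statements on the series, on what has been measured and on what is new or still open speak of the compounds shown alone.

Notes on the shared core. Compound 1 `COc1ccc2c(c1)C(n1ccccc1=O)=CC(C)(C)O2`, compound 2 `CC(=O)c1ccc2c(c1)C(n1ccccc1=O)=CC(C)(C)O2` and compound 3 `CC1(C)C=C(n2ccccc2=O)c2cc(C(=O)c3ccco3)ccc2O1` differ only in the group on one aromatic carbon. In a functional assay (trachea) with Rattus norvegicus as the target (a lower number here means a less potent compound, a higher number a more potent compound, by a factor of ten per unit of this negative logarithm), compound 1 gives 5.99, compound 2 gives 6.65 and compound 3 gives 5.92. Compound 3 sits at the low end of the three: a number 0.73 log units lower from compound 2 to compound 3 (beyond the scatter), while against compound 1 the two numbers lie within the scatter of each other (a number 0.07 log units lower from compound 1 to compound 3 (within the scatter)). The other measured step is a number 0.66 log units higher from compound 1 to compound 2 (beyond the scatter).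

Compound 4 `CC1(C)C=C(n2ccccc2=O)c2cc(C(=O)c3ccccc3C(F)(F)F)ccc2O1` is not yet measured. The change from compound 3 is 2-(trifluoromethyl)phenyl in place of furan-2-yl on a carbonyl carbon. Within the data shown here, the only measured step on the same carbonyl carbon is a number 0.73 log units lower from compound 2 to compound 3 (beyond the scatter), a modest one, which shows that the group on that carbon can move the number. Among the measured compounds shown here, no measured step swaps one aromatic ring for another there, so the direction for compound 4 cannot be read from compound 2 or compound 3. The expected step is therefore small, a number 0.18 log units higher from compound 3 to compound 4 (within the scatter), with a wide spread either way. For compound 4 the estimate is 6.1, expected to fall between 5.4 and 6.8.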

Compound 4, logarithm of the reciprocal of the active concentration, log(1/C): 5.78
For compound 4 the middle estimate is 0.32 log units above the measured one; the measured number falls inside the stated range.
By their numbers in this assay, from the lowest: compounds 4, 3 and 1 (each within the scatter of the next); then compound 2.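

Replacing one aromatic group with another on the carbonyl carbon barely registers in this assay (a number 0.14 log units lower from compound 3 to compound 4 (within the scatter)), even though 2-(trifluoromethyl)phenyl brings 10 heavy atoms against 5 for furan-2-yl. Among the compounds with a carbonyl at this place, both aromatic groups stand apart from methyl, in the same direction (a number 0.73 log units lower from compound 2 to compound 3 (beyond the scatter) and a number 0.87 log units lower from compound 2 to compound 4 (beyond the scatter)), and neither compound 3 nor compound 4 goes against this. Nothing available bears on the cause of these steps.

Going by these compounds, it remains open whether the higher number of compound 2 is particular to methyl or extends to ethyl or a longer chain on the carbonyl carbon. Also open, on these data alone, is whether unsubstituted phenyl, or an amine on that carbon, would fall with the aromatic groups or with methyl.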